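The source may report more compounds than this note shows. Statements on the series, on what has been measured and on what is new or still open speak of the compounds shown alone.

Series of four analogs sharing one core. In an ADME assay on HEK293 cells (Homo sapiens) for cytotoxicity, read by MTT assay, with a stated time of 48 h (on this read-out lower numbers stand for stronger inhibition and higher numbers for weaker inhibition), compound 1 `Cc1nc(-c2ccc(Cl)cc2)sc1C(=O)CSc1nc(-c2ccccc2)c(C#N)c(=O)[nH]1` gives "not determined" (no result reported), and in the same assay compound 3 `Cc1nc(-c2ccccc2)sc1C(=O)CSc1nc(-c2cccc(Cl)c2)c(C#N)c(=O)[nH]1` gives "not determined" (no result reported); for compound 3 no number is available there, as for compound 1. Among the compounds with values here, the only number in the set comes from compound 2 `COc1cccc(-c2nc(SCC(=O)c3sc(-c4ccc(Cl)cc4)nc3C)[nH]c(=O)c2C#N)c1`, which in this assay gives 77900 nM. Compound 4 `Cc1nc(-c2ccc(Cl)cc2)sc1C(=O)CSc1nc(-c2cccc(Cl)c2)c(C#N)c(=O)[nH]1` is the next member and has not yet been measured. From compound 3 to compound 4 the change is chloro in place of hydrogen on an aromatic carbon, phenyl to 4-chlorophenyl at the stated position. Within the data shown here, no measured step exists for this change, so no direction can be read from the data; the step is expected to stay within the usual scatter of this assay. Compound 4 is therefore expected to give about 80000 nM, estimated between 30000 nM and 200000 nM.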

Compound 4, half-maximal inhibitory concentration: 30100 nM
For compound 4 the middle estimate is 2.7-fold (0.42 log units) above the measured one, and the stated range covers the measured number.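

Chloro in place of methoxy on an aromatic carbon gives, in this assay, a 2.6-fold lower number from compound 2 to compound 4 (0.41 log units; beyond the scatter), the first readable step in the series and one beyond the scatter. This position therefore affects the read-out, at least for these two groups. The change from phenyl to 4-chlorophenyl cannot be read, as compound 3 has no number. Nothing available bears on the cause of the step. Still open, going by these compounds, is whether an amine or a carboxylic acid on that aromatic carbon would shift the number further, and how much the 4-chlorophenyl group contributes on its own.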